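The source may report more compounds than this note shows. Statements on the series, on what has been measured and on what is new or still open speak of the compounds shown alone.

Measured so far in an ADME assay on the whole organism (plasma) for pharmacokinetics, with Rattus norvegicus as the target; a lower number here means slower removal, a higher number faster removal of the compound:
- compound 1 `O=S(=O)(c1ccc(C(F)(F)F)cc1)c1cc(F)c(O)c2ncccc12`: 13 mL/min/kg
- compound 2 `Cc1ccc(S(=O)(=O)c2cc(F)c(O)c3ncccc23)cc1`: 27 mL/min/kg

Of these two, compound 2 stands highest at 27 mL/min/kg. Next is compound 3 `O=S(=O)(c1cc(F)c(O)c2ncccc12)N1CCCC1`, with pyrrolidin-1-yl in place of 4-methylphenyl on a sulfonyl sulfur. For the measured compounds named here, the single measured step, a 2.1-fold higher number from compound 1 to compound 2 (0.32 log units; beyond the scatter), is modest and bears only loosely, as it swaps trifluoromethyl for methyl on an aromatic carbon. Going by the values given here, no measured step replaces the whole group on the sulfonyl sulfur, so no firm direction can be drawn from the data. The expected step, a 1.0-fold higher number from compound 2 to compound 3 (0.02 log units; within the scatter), is none beyond the scatter in this assay. For compound 3 the estimate is 28 mL/min/kg, with an expected range of 12 mL/min/kg to 62 mL/min/kg.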

Compound 3, clearance: 11 mL/min/kg
For compound 3 the middle estimate is 2.5-fold (0.41 log units) above the measured one; measured number outside the range, below it.
By their numbers in this assay, from the lowest: compounds 3 and 1 (each within the scatter of the next); then compound 2.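

In this assay, the sulfonyl sulfur need not carry an aryl group: with the whole 4-methylphenyl replaced by pyrrolidin-1-yl, the series shows a 2.5-fold lower number from compound 2 to compound 3 (0.39 log units; beyond the scatter) in this measure of removal. Compound 3 at 11 mL/min/kg and compound 1 at 13 mL/min/kg lie within the scatter of each other, so a non-aromatic ring here matches the trifluoromethyl-bearing aryl compound. No available evidence bears on the reason for this step. As far as these compounds go, whether piperidin-1-yl, morpholin-4-yl or an open-chain diethylamino group on the sulfonyl sulfur would give similar numbers remains open.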